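Three acids on one core and a cyclopropyl variant

The compounds below may be only part of what the source reports. "The series", "measured", "known", "first", "only" and "open" are said of these compounds alone.

Compounds measured so far:
Compound 1, `C[C@@H](C(=O)O)c1nn(Cc2cn3cc(OCC4CC4)c(Cl)cc3n2)c2ccccc2c1=O`, gives 182 nM.
Compound 2, `O=C(O)Cn1nc(Cn2cc3cc(OCC4CC4)c(Cl)cc3n2)c2ccccc2c1=O`, gives 8.1 nM.
Compound 3, `COC(C(=O)O)c1nn(Cc2cn3cc(OCC4CC4)c(Cl)cc3n2)c2ccccc2c1=O`, gives 94 nM.

All three numbers come from a functional assay on HFL1 cells for antagonist activity at sphingosine 1-phosphate receptor 2 (Homo sapiens), read by ELISA, with a stated time of 24 h; on this read-out higher numbers stand for weaker inhibition and lower numbers for stronger inhibition. On that read-out compound 1 stands at the highest value of the three. Its nearest neighbour is compound 3, and the gap from one to the other, a 1.9-fold lower number from compound 1 to compound 3 (0.29 log units; within the scatter), lies within the scatter, so the two cannot be told apart. Within the data shown here, compound 2 is the furthest away, and the gap between compound 1 and compound 2 lies beyond the scatter; no single-point step links them, so only the two values themselves speak.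

Compound 4, `O=C(O)C1(c2nn(Cc3cn4cc(OCC5CC5)c(Cl)cc4n3)c3ccccc3c2=O)CC1`, has not yet been measured. It differs from compound 1 in one place: 1-carboxycyclopropyl in place of 1-carboxyethyl on an aromatic carbon. Among the measured compounds shown here, the one measured step that touches the same position is the change to compound 3, which stayed within the scatter. On that basis the ring-closed acid in compound 4 is expected to sit near compound 1, with the step of a 1.2-fold lower number from compound 1 to compound 4 (0.08 log units; within the scatter) expected to be small. The estimate for compound 4 in this assay is 150 nM, with a range from 50 nM to 500 nM.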

Compound 4, half-maximal inhibitory concentration: 28 nM
The estimate for compound 4 lay 5.4-fold (0.73 log units) above the measured number; the whole stated range lies above it.
By their numbers in this assay, from the lowest: compound 2; then compound 4; then compounds 3 and 1 (each within the scatter of the next).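

The position bearing the acid side chain proved sensitive to change. In this assay, 1-carboxycyclopropyl in place of 1-carboxyethyl gives a 6.5-fold lower number from compound 1 to compound 4 (0.81 log units; beyond the scatter), a step beyond the scatter, whereas the earlier change at this position, to carboxy(methoxy)methyl, stayed within it. The ring also separates from that methoxy-bearing acid, with a 3.4-fold lower number from compound 3 to compound 4 (0.53 log units; beyond the scatter), so among these three side chains 1-carboxycyclopropyl alone stands clear of the other two. Nothing measured here bears on why the number falls.

The step from compound 1 to compound 4 also changes two things at once, since it adds a three-membered ring and removes a defined stereocentre, and the compounds shown cannot separate these two changes. On these data alone, whether an open-chain acid carrying two methyl groups on the carbon attached to the core would match the ring, and whether a cyclobutane ring would do the same, remains open.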